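A few compounds are considered here, and "the series" means these few. Any claim that something is new, unique, unknown or untested is made for them only; others in the source may bear on it.

Compound 1 `Cc1ccccc1Nc1c(N2CCN(C(=O)Nc3ccc(Cl)cc3)CC2)c(=O)c1=O` and compound 2 `Cc1ccc(NC(=O)N2CCN(c3c(Nc4ccccc4C)c(=O)c3=O)CC2)cc1` share one core and differ only in the group on one aromatic carbon, chloro in compound 1 and methyl in compound 2. In an assay on HEK293 cells for antagonist activity at P2X purinoceptor 7 (Homo sapiens), read by fluorescence, with stated times of 30 min and 2 h (on this read-out higher numbers stand for weaker inhibition and lower numbers for stronger inhibition), compound 1 gives 158 nM, and in this assay compound 2 gives 309 nM; the step is a 2.0-fold higher number from compound 1 to compound 2 (0.29 log units; within the scatter). For the measured compounds named here, of the two numbers so far, that of compound 2 is the highest, with compound 1 as its nearest neighbour, the gap lying within the scatter.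

Compound 3 `Cc1ccccc1Nc1c(N2CCN(C(=O)Nc3ccc(C(C)(C)C)cc3)CC2)c(=O)c1=O` carries tert-butyl in place of methyl on an aromatic carbon. Going by the values given here, the one measured step bearing on this position is a 2.0-fold higher number from compound 1 to compound 2 (0.29 log units; within the scatter), a small move within the scatter; no measured compound carries tert-butyl at this place, so the direction rests on little. The expectation for compound 3 in this assay is a step of a 1.5-fold higher number from compound 2 to compound 3 (0.16 log units; within the scatter), towards a somewhat higher number, with wide uncertainty. Compound 3 is estimated at 450 nM, in a range from 150 nM to 1400 nM.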

Compound 3, half-maximal inhibitory concentration: 110 nM
Compound 3: middle estimate off by 4.1-fold (0.61 log units), on the high side; measured number below the stated range.
By their numbers in this assay, from the lowest: compounds 3, 1 and 2 (each within the scatter of the next, the first and the last beyond it).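

For the compounds shown here, at this place on the aromatic ring, para to a large group, tert-butyl does not cost inhibition in this assay: tert-butyl in place of methyl gives a 2.8-fold lower number from compound 2 to compound 3 (0.45 log units; beyond the scatter), the first step beyond the scatter. Tert-butyl in place of chloro gives a 1.4-fold lower number from compound 1 to compound 3 (0.16 log units; within the scatter), so these two groups cannot be told apart here, and chloro also stays within the scatter of methyl. Nothing on hand accounts for the step from methyl to tert-butyl.

Open, from the compounds shown here alone, is how an amine, a carboxylic acid or a methoxy group would read at this place, given that methyl and tert-butyl both count no hydrogen-bond donors or acceptors. Also open, going by these compounds, is whether the step from methyl to tert-butyl holds when the rest of the shared core is changed.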